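This account rests on a few compounds, and the source may have more. Where it says the series, first, only, none or still open, it means among the compounds named here.

Measured compounds:
- compound 1 `COc1ncc(-c2ccc3c(c2)N(c2ccccc2)C(=O)CO3)cc1NS(=O)(=O)c1ccc(F)cc1`: 1530 nM
- compound 2 `COc1ncc(-c2ccc3c(c2)N(C2CC2)C(=O)CO3)cc1NS(=O)(=O)c1ccc(F)cc1`: 6030 nM
- compound 3 `O=C1COc2ccc(-c3cnc(Cl)c(NS(=O)(=O)c4ccc(F)cc4)c3)cc2N1c1ccccc1`: 10300 nM

All three were run in a functional assay on HeLa cells (Homo sapiens) for antiproliferative activity, read by MTT assay, with a stated time of 72 h; on this read-out lower numbers stand for stronger inhibition and higher numbers for weaker inhibition. Compound 1 gives 1530 nM and is the lowest number of the set. Replacing the group on the amide-type nitrogen, (cyclopropyl in place of phenyl on an amide-type nitrogen in a ring), moves the read-out a 3.9-fold higher number from compound 1 to compound 2 (0.60 log units; beyond the scatter). Changing the core instead, (chloro in place of methoxy on an aromatic carbon), moves it a 6.7-fold higher number from compound 1 to compound 3 (0.83 log units; beyond the scatter). Compound 2 and compound 3 lie within the scatter of each other, so no order between them is claimed.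

Compound 4 `O=C1COc2ccc(-c3cnc(Cl)c(NS(=O)(=O)c4ccc(F)cc4)c3)cc2N1C1CC1` is not yet measured in this assay. It differs from compound 3 by cyclopropyl in place of phenyl on an amide-type nitrogen in a ring. This is the same change as that from compound 1 to compound 2, on the same place, on a core that differs only by the chloro in place of methoxy already described. The expectation rests on a single precedent: because the same change gave a 3.9-fold higher number from compound 1 to compound 2 (0.60 log units; beyond the scatter) on the methoxy core, a step of about a 3.4-fold higher number from compound 3 to compound 4 (0.53 log units; beyond the scatter) is expected on the chloro core, with wide uncertainty since the two changes have not been tested together and the starting number for compound 3 is already high. Compound 4 is therefore expected to give roughly 35000 nM, most likely between 12000 nM and 100000 nM, and there is a real chance that only a limit is reported.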

Compound 4, half-maximal inhibitory concentration: 7180 nM
Compound 4: the middle estimate sits 4.9-fold (0.69 log units) above what was measured; measured number below the stated range.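

In this assay, cyclopropyl in place of phenyl on the amide-type nitrogen gives a 1.4-fold lower number from compound 3 to compound 4 (0.16 log units; within the scatter) on the chloro core, so the rise seen on the methoxy core does not carry over: the same change on two cores in this assay, a 3.9-fold higher number (0.60 log units; beyond the scatter) from compound 1 to compound 2 and a 1.4-fold lower number (0.16 log units; within the scatter) from compound 3 to compound 4, 5.7-fold (0.75 log units) apart, beyond the scatter of two such steps

Read from the other side, chloro in place of methoxy gives a 1.2-fold higher number from compound 2 to compound 4 (0.08 log units; within the scatter) with cyclopropyl on the nitrogen, unlike the clear rise with phenyl there: the same change on two cores in this assay, a 6.7-fold higher number (0.83 log units; beyond the scatter) from compound 1 to compound 3 and a 1.2-fold higher number (0.08 log units; within the scatter) from compound 2 to compound 4, 5.7-fold (0.75 log units) apart, beyond the scatter of two such steps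

Taken together, the two changes do not add up across these four compounds, and a step measured on one core is a poor guide to the same step on the other; this single set of four shows that the steps depend on each other, but it does not show why, and it gives no rule for any other group or core.

The compounds shown leave open whether this dependence also holds for other groups on the amide-type nitrogen, such as methyl, benzyl or a pyridine ring. They also leave open how other groups in place of methoxy, such as fluoro, nitrile or an amine, would behave when paired with phenyl and with cyclopropyl.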